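A gem-dimethyl acid in place of the methoxyacetic acid

The source may report more compounds than this note shows. Statements on the series, on what has been measured and on what is new or still open speak of the compounds shown alone.

Measured so far:
compound 1 `CCOc1cc2nn(Cc3nn(CC(=O)O)c(=O)c4ccccc34)cc2cc1Cl` — > 6640 nM
compound 2 `O=C(O)Cn1nc(Cc2nc3cc(Cl)c(OC(F)(F)F)cc3[nH]2)c2ccccc2c1=O` — 31 nM
compound 3 `COC(C(=O)O)c1nn(Cc2cn3cc(OCC4CC4)c(Cl)cc3n2)c2ccccc2c1=O` — 23 nM

In a functional assay on CHO cells for antagonist activity at sphingosine 1-phosphate receptor 2 (Homo sapiens), read by calcium flux (a higher number here means a weaker inhibitor, a lower number a stronger inhibitor), compound 3 gives 23 nM, the lowest of the two numbers recorded. Compound 2 gives 31 nM in this assay, a figure that sits within the scatter of the number for compound 3, so the two cannot be placed in order. For compound 1 this assay reports only a limit, > 6640 nM (the limit of > 6640 nM in this assay, at which 1 of the 3 values shown sits), and not a number.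

Compound 4 `CC(C)(C(=O)O)c1nn(Cc2cn3cc(OCC4CC4)c(Cl)cc3n2)c2ccccc2c1=O` has not yet been measured. It differs from compound 3 in one place: 1-carboxy-1-methylethyl in place of carboxy(methoxy)methyl on an aromatic carbon. Among the measured compounds shown here, no step between measured compounds bears on this change; the three measured compounds differ from one another in several places at once, so no single difference can be read off them. The expectation is therefore cautious: the step of a 1.7-fold higher number from compound 3 to compound 4 (0.24 log units; within the scatter) is expected to stay within the scatter, with a slight lean toward a weaker inhibitor, since the acid keeps its carboxyl but loses the methoxy oxygen. Compound 4 is expected to give about 40 nM in this assay, with a range from 12 nM to 150 nM.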

Compound 4, half-maximal inhibitory concentration: 7.7 nM
Estimate against measurement, compound 4: 5.2-fold (0.72 log units) above; measured number below the stated range.
By their numbers in this assay, from the lowest: compound 4; then compounds 3 and 2 (each within the scatter of the next). At a limit, above all of these: compound 1.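

Among the compounds shown here, the first step that changes one place alone is the replacement of carboxy(methoxy)methyl by 1-carboxy-1-methylethyl on the aromatic carbon next to the ring nitrogen, and in this assay it gives a 3.0-fold lower number from compound 3 to compound 4 (0.48 log units; beyond the scatter). It shows that this position takes the change with no loss: the methoxy oxygen is not needed to keep the number low, and a carbon carrying two methyl groups alongside the carboxyl serves at least as well. The earlier compounds shown here could not show this, since they differ from one another in several places at once. For the compounds shown here, nothing measured here accounts for the gain, and the single step offers no property of either group to set against it.

The compounds shown leave open whether a single methyl on that carbon, two ethyl groups or a cyclopropane ring closed through it would give the same result, and which of the two methyl groups matters. They also leave open whether the step would carry over to the core of compound 2, or hold with a tetrazole in place of the carboxylic acid.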